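Stereo drawing at the chain carbon

The source may hold more compounds than are shown below. What is called first, only, known or untested is meant among the compounds shown, and "the series" means these compounds.

Of the compounds shown here, three have been read so far in an ADME assay on microsomes from liver (Mus musculus, strain CD-1) for metabolic stability, read by LC-MS, with a stated time of 60 min, tested at 20 uM (a lower number here means that the compound disappears faster, a higher number that the compound lasts longer), for this series. Compound 1 `CC(Sc1nc2nn(CC3COC3)cc2c(=O)n1-c1ccccc1)c1ccccc1` stands at 0.317 h and compound 3 `CC(Sc1nc2nn(C3COC3)cc2c(=O)n1-c1ccccc1)c1ccccc1` at 0.783 h on this scale, while compound 2 `C[C@@H](Sc1nc2c(cnn2C)c(=O)n1-c1ccccc1)c1ccccc1` sits at 0.133 h as the lowest of the three, with its gaps to both others beyond the scatter.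

Compound 4 `CC(Sc1nc2c(cnn2C)c(=O)n1-c1ccccc1)c1ccccc1` is read against compound 2: the two compounds have the same atoms and bonds; at least one stereo element is drawn with a configuration in one of them and without one in the other: 1 of 1 stereo elements differ; a stereocentre at a saturated chain carbon is drawn R in compound 2 and without a configuration in compound 4 is the whole change, the two compounds having the same atoms and bonds, with the stereocentre at a saturated chain carbon drawn R in compound 2 and without a configuration in compound 4.

Going by the values given here, the one measured step between close neighbours, a 2.5-fold higher number from compound 1 to compound 3 (0.39 log units; beyond the scatter) with oxetan-3-yl in place of (oxetan-3-yl)methyl on an aromatic nitrogen, is modest and lies beyond the scatter. Among the compounds with values here, it concerns that nitrogen substituent and not the stereocentre, so its size does not carry over, and no measured pair isolates a change in configuration.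

The expectation therefore rests on compound 2 at 0.133 h as the anchor in this assay with no step beyond the scatter foreseen. The expected step is a 1.1-fold higher number from compound 2 to compound 4 (0.05 log units; within the scatter) and it is estimated to stay within the scatter. For compound 4 the expected half-life is 0.15 h (estimated range from 0.08 h to 0.3 h).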

Compound 4, half-life: 0.133 h
Compound 4: middle estimate off by 1.1-fold (0.05 log units), on the high side; measured number inside the range.
By their numbers in this assay, from the lowest: compounds 2 and 4 (each within the scatter of the next); then compound 1; then compound 3.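

In this assay, the pair at the chain carbon shows no change at the digits printed from compound 2 to compound 4 (within the scatter), so the drawing at this position does not separate the two compounds on this scale. Going by these compounds alone, the one earlier step changed only the substituent on the aromatic nitrogen, which left the stereocentre untested until this pair. The result is a comparison of a defined drawing with an undefined one, not of two defined configurations, and that limits how far it can be read: the fact that one of compounds 2 and 4 is drawn with a defined configuration and the other without, at the place where they differ

The compounds shown leave open what a chain carbon drawn S would give, and whether the same flat reading holds with oxetan-3-yl on the aromatic nitrogen, as in compound 3, rather than with the substituent shared by compound 2 and compound 4. Also open, from the compounds shown here alone, is whether a longer chain or an amine at the chain carbon would shift the half-life beyond the scatter, given that the shared core has so far been read here with only this one arrangement at that carbon.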